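The source may report more compounds than this note shows. Statements on the series, on what has been measured and on what is new or still open speak of the compounds shown alone.

Working notes on the series. All members share one core, varied at a single aromatic carbon. Compound 1 `COc1cccc(CCCCCC(=O)N2CCOC2=O)c1` carries a methoxy there; in an assay on HEK293 cells for inhibition of N-acylethanolamine-hydrolyzing acid amidase (Rattus norvegicus), read by LC-MS, with a stated time of 30 min (on this read-out lower numbers stand for stronger inhibition and higher numbers for weaker inhibition), compound 1 gives 16300 nM. Compound 2 `O=C(CCCCCc1cccc(CO)c1)N1CCOC1=O` carries a hydroxymethyl at the same carbon. For compound 2 this assay returns only a limit, > 20000 nM. Compound 3 `O=C(O)c1cccc(CCCCCC(=O)N2CCOC2=O)c1` carries a carboxy. For compound 3 this assay likewise returns only a limit, > 20000 nM. Compound 3 therefore stands at the limit of > 20000 nM in this assay, at which 2 of the 3 values shown sit, and no number is known for it, only that it sits past that limit. The steps from the methoxy compound are bounded on one side only: an at least 1.2-fold higher number from compound 1 to compound 2 (0.08 log units; that floor lies within the scatter) and an at least 1.2-fold higher number from compound 1 to compound 3 (0.08 log units; that floor lies within the scatter). Between the two limits, a step that the two limits leave unreadable from compound 2 to compound 3.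

Compound 4 `Cc1cccc(CCCCCC(=O)N2CCOC2=O)c1` changes compound 3 by methyl in place of carboxy on an aromatic carbon. For the measured compounds named here, no measured pair shows this exact exchange. Going by the values given here, the only firm number belongs to compound 1, whose methoxy occupies the same carbon and gives 16300 nM in this assay. Methyl, like methoxy, is a small neutral group without donor or acceptor, so compound 4 is expected to come back toward that region rather than to stay where compound 3 sits. Compound 4 is estimated at 12000 nM, within 4000 nM to 30000 nM. The expected step is an at least 1.6-fold lower number from compound 3 to compound 4 (0.22 log units; that floor lies within the scatter), toward a lower number, though its size cannot be read from a limit.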

Compound 4, half-maximal inhibitory concentration: 350 nM
Compound 4: middle estimate off by 34-fold (1.54 log units), on the high side, outside the stated range (below it).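

In this assay, for the compounds shown here, the group at this one aromatic carbon can move the read-out far beyond the scatter, which the earlier compounds, with one firm number and two limits, could not show: the only step with two firm ends is a 47-fold lower number from compound 1 to compound 4 (1.67 log units; beyond the scatter). Methyl also stands well apart from the carboxy and the hydroxymethyl, with an at least 57-fold lower number from compound 3 to compound 4 (1.75 log units; beyond the scatter) and an at least 57-fold lower number from compound 2 to compound 4 (1.75 log units; beyond the scatter), and since all three steps are printed as beyond the scatter, compound 4 is the most potent of the four shown. The last two steps are floors only, as their weaker ends are limits and not numbers: the limit of > 20000 nM in this assay, at which 2 of the 4 values shown sit.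

Still open, from the compounds shown here alone, is whether hydrogen, ethyl, chlorine or an amine at this carbon would read nearer compound 4 or nearer compound 1, and whether methyl on another carbon of the ring would keep the lower number. The step between compound 2 and compound 3 cannot be read, so those two cannot be placed in any order.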